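A few compounds are considered here, and "the series" means these few. Any claim that something is new, unique, unknown or untested is made for them only; others in the source may bear on it.

Among the measured compounds shown here, in an assay on isolated protein (Cavia porcellus) with Sigma non-opioid intracellular receptor 1 (Homo sapiens) as the target, read by radioligand binding (on this read-out lower numbers stand for stronger inhibition and higher numbers for weaker inhibition), compound 1 `CN(C)CCCCCCOc1ccc2oc(-c3ccccc3)cc(=O)c2c1` gives 432 nM, the highest of the three numbers known so far. Compound 2 `O=c1cc(-c2ccccc2)oc2ccc(OCCCCCCN3CCC(O)CC3)cc12` gives 100 nM and compound 3 `O=c1cc(-c2ccccc2)oc2ccc(OCCCCCCN3CCCC(O)C3)cc12` gives 86 nM; the step of a 1.2-fold lower number from compound 2 to compound 3 (0.07 log units; within the scatter) stays within the scatter. Compound 4 `CN(CCCCCCOc1ccc2oc(-c3ccccc3)cc(=O)c2c1)Cc1ccccc1` carries phenyl in place of hydrogen on a saturated chain carbon bound to an amine nitrogen, that is, methyl to benzyl and dimethylamino to benzyl(methyl)amino. For the measured compounds named here, no measured step makes this exact change; the nearest guidance comes from the steps of a 4.3-fold lower number from compound 1 to compound 2 (0.64 log units; beyond the scatter) and a 5.0-fold lower number from compound 1 to compound 3 (0.70 log units; beyond the scatter), in which a larger amine in place of dimethylamino lowered the number each time, so a lowering beyond the scatter, though of smaller size, is expected for compound 4 as well. Compound 4 is therefore estimated at 150 nM, between 50 nM and 500 nM, a step of a 2.9-fold lower number from compound 1 to compound 4 (0.46 log units; beyond the scatter).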

Compound 4, half-maximal inhibitory concentration: 52 nM
Compound 4: middle estimate off by 2.9-fold (0.46 log units), on the high side; the range from low to high includes it.
By their numbers in this assay, from the lowest: compounds 4, 3 and 2 (each within the scatter of the next); then compound 1.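

In this assay, phenyl in place of hydrogen on a saturated chain carbon bound to an amine nitrogen gives an 8.3-fold lower number from compound 1 to compound 4 (0.92 log units; beyond the scatter), so a larger amine without a hydroxy group also goes with a lower number than dimethylamino. Benzyl(methyl)amino cannot be told apart from either hydroxypiperidinyl group, with a 1.7-fold lower number from compound 3 to compound 4 (0.22 log units; within the scatter) and a 1.9-fold lower number from compound 2 to compound 4 (0.28 log units; within the scatter) both within the scatter. Nothing available explains this result. The compounds shown leave open how a plain piperidin-1-yl or a phenethyl(methyl)amino group would read. They also leave open whether a shorter chain would keep these numbers.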